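The compounds below may be only part of what the source reports. "The series", "measured", "known", "first", "only" and "open" are said of these compounds alone.

Measured so far, in a functional assay on HeLa cells (Homo sapiens) for inhibition, read by MTT assay, with a stated time of 48 h; a lower number here means a stronger inhibitor, a higher number a weaker inhibitor:
compound 1 `COc1cccc(NC(=O)/C=C/c2coc3cc(OC)ccc3c2=O)c1` gives 19200 nM.
compound 2 `O=C(/C=C/c1coc2cc(O)ccc2c1=O)NCc1ccc(F)cc1` gives only an assay limit, > 100000 nM.
compound 3 `COc1ccc(NC(=O)/C=C/c2coc3cc(O)ccc3c2=O)cc1` gives only an assay limit, > 100000 nM.

Within the data shown here, compound 1 therefore holds the only true number in this assay; the two other values sit at the limit of > 100000 nM in this assay, at which 2 of the 3 values shown sit. The step that the two limits leave unreadable from compound 2 to compound 3 cannot be read because both of its ends are limits, so it gives no guidance.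

Compound 4 `COc1ccc2c(=O)c(/C=C/C(=O)Nc3ccccc3OC)coc2c1` differs from compound 1 by 2-methoxyphenyl in place of 3-methoxyphenyl on an amide-type nitrogen. Among the measured compounds shown here, no measured step touches this kind of change, so nothing seen so far points to a shift in either direction, and the step of a 1.0-fold lower number from compound 1 to compound 4 (0.00 log units; within the scatter) is expected to stay within the scatter. Compound 4 is thus estimated at 19000 nM, between 6000 nM and 60000 nM.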

Compound 4, half-maximal inhibitory concentration: > 100000 nM
Compound 4: a limit, no number; the forecaster's own chance of this, stated with the estimate: 20%; middle value at least 5.2-fold (0.72 log units) from the limit.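

Swapping 3-methoxyphenyl for 2-methoxyphenyl on the amide-type nitrogen, with the same atoms joined differently, gives an at least 5.2-fold higher number from compound 1 to compound 4 (0.71 log units; beyond the scatter). The value of compound 4, > 100000 nM, is a limit and not a number. So where the methoxy sits on this ring can by itself weaken the compound in this assay, which the earlier compounds could not show.

As far as these compounds go, how large the loss really is stays open, and compound 1 remains the only anchor: the limit of > 100000 nM in this assay, at which 3 of the 4 values shown sit. Also open is whether an amine or a carboxylic acid in place of the methoxy group of compound 1 would strengthen or weaken it.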